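Three biaryl amides at the cytotoxicity limit, and a chloro analogue

The compounds below may be only part of what the source reports. "The series", "measured", "known", "first", "only" and "open" are said of these compounds alone.

Compound 1: `CCOC(=O)CCCCCOc1cccc(CN(C(=O)c2ccc(-c3cccc(OCC(C)C)c3)cc2)C(C)C)c1` gives > 26000 nM in an ADME assay on HEK293 cells (Homo sapiens) for cytotoxicity, read by CellTiter-Glo and resazurin assay, with a stated time of 72 h; on this read-out higher numbers stand for an effect only at larger amounts of compound and lower numbers for an effect already at smaller amounts.
Compound 2: `CCOC(=O)CCCCCOc1cccc(CN(C(=O)c2ccc(-c3cccc(C(F)(F)F)c3)cc2)C(C)C)c1` gives > 26000 nM in this assay.
Compound 3: `CCOC(=O)CCCCCOc1cccc(CN(C(=O)c2ccc(-c3cccc(Br)c3)cc2)C(C)C)c1` gives > 26000 nM in this assay.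

All three values are limits of the assay, not numbers. For compound 3 the reading is a limit, > 26000 nM, and the same limit holds for the other two compounds shown. Because of the limit of > 26000 nM in this assay, at which 3 of the 3 values shown sit, none of the pairwise steps can be read: a step that the two limits leave unreadable from compound 1 to compound 2, a step that the two limits leave unreadable from compound 1 to compound 3 and a step that the two limits leave unreadable from compound 2 to compound 3 all sit between two limits, and their sizes are not readable.

Compound 4 is `CCOC(=O)CCCCCOc1cccc(CN(C(=O)c2ccc(-c3cccc(Cl)c3)cc2)C(C)C)c1`. It differs from compound 3 in one place: chloro in place of bromo on an aromatic carbon. The difference is therefore a halogen swap on the same aromatic carbon of the shared core. Nothing among the measured steps bears on it in a readable way, since every step shown is between two limits. What can be said is that three different groups at this position all leave the compound at the limit in this assay. On that basis compound 4 is expected to behave the same way, with the estimated step that the limit leaves unreadable from compound 3 to compound 4 being no more than scatter, and compound 4 is estimated at 40000 nM, in the range 15000 nM to 120000 nM, most likely reported again as a limit.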

Compound 4, half-maximal effective concentration: > 18400 nM
Compound 4: a limit, no number (the forecaster's own chance of this, stated with the estimate: 85%); the middle value does not contradict the limit.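

In this assay compound 4 gives > 18400 nM, which is a limit and not a number. The steps linking compound 4 with compound 1, compound 2 and compound 3 all join two limits and cannot be read. The compounds shown leave open what number any of the four would reach in this assay, and whether chloro, bromo, trifluoromethyl and isobutoxy differ there at all.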